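Ring closure of the side chain on compound 2

This account rests on a few compounds, and the source may have more. Where it says the series, first, only, none or still open, it means among the compounds named here.

Compound 2 `COc1cccc(-c2c(C)n(Cc3c(F)cccc3F)c(=O)n([C@H](C)CNCc3ccc(F)cc3)c2=O)c1` gives 250 nM in an assay on HEK293 cells for binding affinity to Gonadotropin-releasing hormone receptor (Homo sapiens) (a higher number here means a weaker inhibitor, a lower number a stronger inhibitor), the highest of the two numbers recorded so far. Its nearest neighbour is compound 1 `COc1cccc(-c2c(C)n(Cc3c(F)cccc3F)c(=O)n([C@H](C)CNCc3ccccc3)c2=O)c1`, which in this assay gives 75 nM; the step of a 3.3-fold higher number from compound 1 to compound 2 (0.52 log units; beyond the scatter) is the only one available in this series.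

Compound 3 `COc1cccc(-c2c(C)n(Cc3c(F)cccc3F)c(=O)n(C3CCN(Cc4ccccc4)C3)c2=O)c1` is not yet measured. It differs from compound 2 by 1-benzylpyrrolidin-3-yl in place of 1-(((4-fluorobenzyl)amino)methyl)ethyl on an aromatic nitrogen. This removes the fluorine whose introduction gave a 3.3-fold higher number from compound 1 to compound 2 (0.52 log units; beyond the scatter), and at the same time ties the chain into a ring, so the hydrogen-bond donor counted on the leaving group is gone. Going by the values given here, no measured step covers the ring closure, so only the fluorine part can be read from the data.

Going by these compounds, on that basis compound 3 is expected to move back toward the number of compound 1, roughly undoing the loss in a 3.3-fold higher number from compound 1 to compound 2 (0.52 log units; beyond the scatter), with wide uncertainty because the ring closure is untested; the expected step is a 2.5-fold lower number from compound 2 to compound 3 (0.40 log units; beyond the scatter). The estimate for compound 3 in this assay is 100 nM, within a range from 25 nM to 400 nM.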

Compound 3, inhibition constant: 280 nM
The estimate for compound 3 lay 2.8-fold (0.45 log units) below the measured number; low and high end bracket the measured number.
By their numbers in this assay, from the lowest: compound 1; then compounds 2 and 3 (each within the scatter of the next).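

In this assay, the step of a 1.1-fold higher number from compound 2 to compound 3 (0.05 log units; within the scatter) shows that, at this aromatic nitrogen, 1-benzylpyrrolidin-3-yl and 1-(((4-fluorobenzyl)amino)methyl)ethyl cannot be told apart, even though the entering group has a five-membered non-aromatic ring, no hydrogen-bond donor and no defined stereocentre. The comparison without fluorine on either side reads differently: a 3.7-fold higher number from compound 1 to compound 3 (0.57 log units; beyond the scatter) shows that 1-benzylpyrrolidin-3-yl does not match 1-((benzylamino)methyl)ethyl, leaving compound 1 with the lowest number of the three, with both of its steps beyond the scatter. No measurement available here accounts for either step.

Going by these compounds, it remains open whether the gap to compound 1 goes with the ring itself or with the loss of the hydrogen-bond donor, a question that a methyl group on the chain amine of compound 1 could separate. Also open, on these data alone, are the effect of a 4-fluorobenzyl group on the pyrrolidine nitrogen, the response to a six-membered piperidine ring in place of the pyrrolidine, and any difference between the two separate pyrrolidine stereoisomers.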